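The compounds below may be only part of what the source reports. "The series", "measured", "known", "first", "only" and "open" are said of these compounds alone.

In a physicochemical assay for lipophilicity (on this read-out lower numbers stand for lower lipophilicity and higher numbers for higher lipophilicity), compound 1 (`CC(C)(C)c1ccc2c(c1)c(NO)cc[n+]2[O-]`) gives 2.05, compound 2 (`O=[N+]([O-])c1cc[n+]([O-])c2ccc(C3CCCCC3)cc12`) gives 2.8, and compound 3 (`CCCCc1ccc2c(c1)c([N+](=O)[O-])cc[n+]2[O-]`) gives 3.11, the highest of the three numbers. Compound 4 (`CC(C)(C)c1ccc2c(c1)c([N+](=O)[O-])cc[n+]2[O-]`) has not yet been measured. It differs from compound 3 by tert-butyl in place of butyl on an aromatic carbon. Among the measured compounds shown here, the only measured step that bears on this change is a number 0.31 log units higher from compound 2 to compound 3 (beyond the scatter), a modest change beyond the scatter on swapping cyclohexyl for butyl. A step no larger than that one, and downward, is therefore expected, and it may stay within the scatter. The estimated step is a number 0.21 log units lower from compound 3 to compound 4 (within the scatter). For compound 4 the expected value is 2.9, with an estimated range of 2.6 to 3.2.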

Compound 4, partition coefficient: 3.06
The estimate for compound 4 lay 0.16 log units below the measured number; the measured number falls inside the stated range.
By their numbers in this assay, from the lowest: compound 1; then compounds 2, 4 and 3 (each within the scatter of the next, the first and the last beyond it).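

In this assay, tert-butyl in place of butyl on an aromatic carbon gives a number 0.05 log units lower from compound 3 to compound 4 (within the scatter), and tert-butyl in place of cyclohexyl gives a number 0.26 log units higher from compound 2 to compound 4 (within the scatter), so at this position tert-butyl cannot be told apart from either group, although those two differ beyond the scatter. At the other position, nitro in place of hydroxyamino gives a number 1.01 log units higher from compound 1 to compound 4 (beyond the scatter), the largest of these steps. No supporting data explain these steps.

From the compounds shown here alone, whether methyl or a longer chain at the first position would stay close to these values remains open. So does how an amine in place of nitro would compare.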